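A few compounds are considered here, and "the series" means these few. Any claim that something is new, unique, unknown or untested is made for them only; others in the source may bear on it.

In a functional assay on WiDr cells (Homo sapiens) for inhibition, read by sulforhodamine B assay, with a stated time of 48 h (a lower number here means a stronger inhibitor of growth, a higher number a weaker inhibitor of growth), compound 2 `CC(=O)OC/C(=C\c1ccc(Cl)cc1)C(=O)c1ccccc1` gives 4800 nM, the lowest of the three numbers recorded so far, with each of the other two compounds standing a step away that lies beyond the scatter. Compound 1 `O=C(/C(=C/c1ccc(Cl)cc1)CCl)c1ccccc1` gives 19000 nM. The step between these two is a 4.0-fold lower number from compound 1 to compound 2 (0.60 log units; beyond the scatter). Compound 3 `CC(=O)OC/C(=C\c1ccccc1F)C(=O)c1ccccc1` gives 19000 nM, and the step here is a 4.0-fold higher number from compound 2 to compound 3 (0.60 log units; beyond the scatter).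

Compound 4 `CC(=O)OC/C(=C\c1ccc([N+](=O)[O-])cc1)C(=O)c1ccccc1` has not yet been measured in this assay. It differs from compound 2 in one place: nitro in place of chloro on an aromatic carbon. Going by the values given here, of the two measured steps, only one alters the aromatic ring that sits on the double-bonded chain carbon, and it was modest: a 4.0-fold higher number from compound 2 to compound 3 (0.60 log units; beyond the scatter). Among the compounds with values here, that step, however, changed the halogen and its position on the ring at once, so nothing measured separates the group from its place, and no measured step shows nitro in place of chloro at all. The step from compound 1 to compound 2 concerns the saturated chain carbon and does not bear on this change.

A modest step, of uncertain direction and leaning toward a somewhat higher number, is therefore expected in this assay, namely a 1.5-fold higher number from compound 2 to compound 4 (0.16 log units; within the scatter). Compound 4 is estimated at 7000 nM, within a range from 2500 nM to 20000 nM.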

Compound 4, concentration for 50% growth inhibition: 23000 nM
Compound 4: the middle estimate sits 3.3-fold (0.52 log units) below what was measured; measured number above the stated range.
By their numbers in this assay, from the lowest: compound 2; then compounds 1, 3 and 4 (each within the scatter of the next).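

In this assay the move from chloro to nitro, on an aromatic carbon para to a large group, is not a neutral exchange: it gives a 4.8-fold higher number from compound 2 to compound 4 (0.68 log units; beyond the scatter) and so lies beyond the scatter. Going by these compounds alone, this is the first step that alters the group while leaving its place on the ring unchanged, which shows that the group alone can shift the number at this position, something that a 4.0-fold higher number from compound 2 to compound 3 (0.60 log units; beyond the scatter) could not show with the halogen and its position changed at once. Nothing available here accounts for the direction or size of this step.

The compounds shown leave open how an amine or a carboxylic acid at this same place would read, and whether fluoro there would stand closer to chloro or to nitro. They also leave open whether nitro on another carbon of the ring would give a similar step, and whether the change on the saturated chain carbon seen in a 4.0-fold lower number from compound 1 to compound 2 (0.60 log units; beyond the scatter) would recur with nitro on the ring.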